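A few compounds are considered here, and "the series" means these few. Any claim that something is new, unique, unknown or untested is made for them only; others in the source may bear on it.

Measured in an ADME assay on the whole organism (strain Sprague-Dawley) for pharmacokinetics, with Rattus norvegicus as the target, read by LC-MS; a higher number here means that a larger share of the oral dose reaches the circulation, a lower number that a smaller share of the oral dose reaches the circulation:
- compound 1 `O=c1[nH]ccn1CCOc1nn(-c2ccccc2F)c2ccc(F)cc12`: 35%
- compound 2 `O=C1N(c2ccncc2)CCN1c1cccc2c1cnn2-c1ccccc1F`: 28%

In this assay, compound 2 gives 28% and compound 1 gives 35%. These two values lie within the scatter of each other, so neither can be ranked above the other. Within the data shown here, the two compounds also differ in more than one place, which means that no single structural step has a measured size yet.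

The next compound is compound 3 `O=C1N(Cc2ncco2)CCN1c1cccc2c1cnn2-c1ccccc1F`, which keeps everything in compound 2 apart from one group: (1,3-oxazol-2-yl)methyl in place of pyridin-4-yl on an amide-type nitrogen in a ring. In words, (1,3-oxazol-2-yl)methyl stands in place of pyridin-4-yl on an amide-type nitrogen in a ring.

Among the measured compounds shown here, the data offer no precedent for this exchange, so no direction can be argued for it. For the measured compounds named here, the only anchor is compound 2 at 28%. With nothing to suggest otherwise, the expected result is no shift beyond the scatter, and the estimated change is a number 1 percentage points lower from compound 2 to compound 3 (within the scatter). The wide range reflects how little two measurements can support. For compound 3 the expected value is 27%, with an estimated range of 10% to 48%.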

Compound 3, oral bioavailability: 37%
Compound 3: the middle estimate sits 10 percentage points below what was measured; measured number inside the range.
By their numbers in this assay, from the lowest: compounds 2, 1 and 3 (each within the scatter of the next).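

At the amide-type nitrogen in the five-membered non-aromatic ring, this assay now has its first step in one place: a number 9 percentage points higher from compound 2 to compound 3 (within the scatter), with (1,3-oxazol-2-yl)methyl in place of pyridin-4-yl. This position therefore accepts a substantial exchange, from a six-membered aromatic ring with 1 hetero atom to a five-membered aromatic ring with 2 hetero atoms and from 1 hydrogen-bond acceptor to 2, at an unchanged count of 6 heavy atoms, without a shift beyond the scatter in the share of the oral dose that reaches the circulation. No supporting data are available to explain the size of this step or to attribute it to any feature of either group.

Open at this nitrogen is how far the read-out holds for groups of another kind, such as a carboxylic acid, an amine or a longer chain ending in the same 1,3-oxazol-2-yl ring. Also open, going by these compounds, is whether the same exchange gives a step of similar size on another core, as this single pair gives no information beyond the shared core of compound 2 and compound 3.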